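The compounds below may be only part of what the source reports. "The series", "measured", "known", "first", "only" and "open" are said of these compounds alone.

Of the compounds shown here, two that share one core have so far been tested in a functional assay on the whole organism with Mus musculus as the target, in the writhing test, at a dose of 100 mg/kg by the intraperitoneal route; a higher number here means more inhibition at the dose given (going by the name of the read-out), a lower number less inhibition. Compound 1 `Clc1ccc(OCCOc2nc3ccccc3s2)cc1` carries a chloro group, and in this assay compound 1 gives 68.6%. Compound 2 `Fc1ccc(OCCOc2nc3ccccc3s2)cc1` carries a fluoro group on the same aromatic carbon, and in this assay compound 2 gives 99.9%. That is the highest of the two numbers, and the step of a number 31.3 percentage points higher from compound 1 to compound 2 (beyond the scatter) is large and beyond the scatter.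

Compound 3 `c1ccc(OCCOc2nc3ccccc3s2)cc1` has not yet been measured. Its change from compound 2 is hydrogen in place of fluoro on an aromatic carbon. Among the measured compounds shown here, the one measured step, a number 31.3 percentage points higher from compound 1 to compound 2 (beyond the scatter), bears on this only in part: it shows that exchanging one halogen for another at this carbon moved the read-out a long way, but it says nothing about removing the halogen altogether. The number for compound 2 is already the higher of the two and leaves little room above it, so there is far more room for the number to fall than to rise. A fall of moderate size is therefore expected, with wide uncertainty, a number 29.9 percentage points lower from compound 2 to compound 3 (beyond the scatter). Compound 3 is expected to give 70% in this assay, within a range from 40% to 100%.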

Compound 3, a percentage reported as inhibition, in the whole organism at one dose (the size of the read-out at that dose, not a potency): "not active" (no number reported)
The entry for compound 3 holds no number; there is nothing to compare the estimate with.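

Among the compounds shown here, the entry for compound 3 in this assay holds no number, so no step from compound 2 to compound 3 can be read. Nothing measured here bears on the reason for this result. The compounds shown leave open how large a change in the read-out comes with hydrogen in place of fluoro on this aromatic carbon.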